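The source may report more compounds than this note shows. Statements on the series, on what has been measured and on what is new or still open speak of the compounds shown alone.

Values in a functional assay on PANC-1 cells (Homo sapiens) for inhibition, read by MTT assay, with a stated time of 24 h; on this read-out higher numbers stand for weaker inhibition and lower numbers for stronger inhibition:
- Compound 1 `CC1(C)[C@H]2CC[C@]1(C)N(Cc1cn(-c3ccccc3Br)nn1)C(=O)C2`: 280 nM
- Compound 2 `CC1(C)[C@H]2CC[C@]1(C)N(Cc1cn(-c3cccc(C#N)c3)nn1)C(=O)C2`: 260 nM
- Compound 3 `COc1ccccc1-n1cc(CN2C(=O)C[C@@H]3CC[C@@]2(C)C3(C)C)nn1`: 120 nM

Compound 3 has the lowest number of the three. Compound 4 `CC1(C)[C@H]2CC[C@]1(C)N(Cc1cn(-c3ccccc3)nn1)C(=O)C2` differs from it by hydrogen in place of methoxy on an aromatic carbon, with hydrogen in place of methoxy on an aromatic carbon. Among the compounds with values here, no measured compound carries the plain phenyl, so the evidence is indirect. The measured steps to the 2-methoxyphenyl were modest: a 2.3-fold lower number from compound 1 to compound 3 (0.37 log units; beyond the scatter) and a 2.2-fold lower number from compound 2 to compound 3 (0.34 log units; beyond the scatter). The other step, a 1.1-fold lower number from compound 1 to compound 2 (0.03 log units; within the scatter), stayed within the scatter. Losing the methoxy is therefore expected to bring a small rise in the number in this assay, perhaps no more than the scatter. The expected change is a 1.8-fold higher number from compound 3 to compound 4 (0.24 log units; within the scatter). For compound 4 the estimated value is 210 nM, with an expected range from 100 nM to 450 nM.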

Compound 4, half-maximal inhibitory concentration: 160 nM
For compound 4 the middle estimate is 1.3-fold (0.12 log units) above the measured one, and the stated range covers the measured number.
By their numbers in this assay, from the lowest: compounds 3, 4, 2 and 1 (each within the scatter of the next, the first and the last beyond it).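

The plain phenyl of compound 4 sits within the scatter of all three substituted rings in this assay: a 1.3-fold higher number from compound 3 to compound 4 (0.12 log units; within the scatter), a 1.6-fold lower number from compound 2 to compound 4 (0.21 log units; within the scatter) and a 1.8-fold lower number from compound 1 to compound 4 (0.24 log units; within the scatter). The methoxy therefore shows no edge over hydrogen that can be told from the scatter, and neither bromo nor cyano can be told from hydrogen either, although the methoxy compound stands apart from those two. Nothing measured here bears on why this is so. As far as these compounds go, whether an amine, a carboxylic acid or a longer alkoxy chain on this ring would move the number beyond the scatter remains open.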